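The compounds below may be only part of what the source reports. "The series", "measured", "known", "first", "only" and "open" are said of these compounds alone.

Two compounds share one core and differ only in the group hung on it. Compound 1 `CCCCCNc1nn2c(=O)cc(C(F)(F)F)nc2s1` carries a five-carbon chain joined through an amine, and in an ADME assay on cells for inhibition of Intestinal-type alkaline phosphatase (Homo sapiens), read by luminescence, with stated times of 7 min and 20 min (a lower number here means a stronger inhibitor, a higher number a weaker inhibitor), compound 1 gives 760 nM. Compound 2 `COc1ccccc1-c1nn2c(=O)cc(C(F)(F)F)nc2s1` carries instead an aromatic ring bearing a methoxy group. In this assay compound 2 reaches only the limit of the assay, > 100000 nM, so for it no true number is known. This is the limit of > 100000 nM in this assay, at which 1 of the 2 values shown sits. Going by the values given here, on the two values shown, compound 2 thus stands at the weak end, while compound 1 is the one with a measured number.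

Compound 3 `CCOc1ccccc1-c1nn2c(=O)cc(C(F)(F)F)nc2s1` differs from compound 2 in one place: methyl in place of hydrogen on a saturated chain carbon bound to an oxygen on an aromatic ring, so that methoxy becomes ethoxy. This is a small addition on the outer edge of the molecule. The expected step that the limit leaves unreadable from compound 2 to compound 3 is none beyond the usual scatter. In this assay compound 3 is therefore expected to give about 150000 nM, within a range from 30000 nM to 600000 nM, and most likely it will again be reported as a limit rather than a number.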

Compound 3, half-maximal inhibitory concentration: > 100000 nM
Compound 3 was reported as a limit; the forecaster's own chance of this, stated with the estimate: 80%; the middle value is on the limit's open side.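

No step from compound 2 to compound 3 can be read, because each is reported only as a limit and not as a true number: the limit of > 100000 nM in this assay, at which 2 of the 3 values shown sit.

The compounds shown leave open how strongly compound 2 and compound 3 really inhibit in this assay, and whether changing methoxy to ethoxy makes any difference there.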